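Solubility of Benzotriazine Dioxides with Amine Side Chains

The source may report more compounds than this note shows. Statements on the series, on what has been measured and on what is new or still open speak of the compounds shown alone.

Compound 1 `[O-][n+]1nc(NCCN2CCCCC2)[n+]([O-])c2ccccc21` sits at a limit of a physicochemical assay for solubility, in the presence of a further agent that is not named here; on this read-out higher numbers stand for higher solubility and lower numbers for lower solubility: compound 1 gives > 49000000 nM. Compound 2 `CCCN(CCC)CCNc1n[n+]([O-])c2ccccc2[n+]1[O-]` also reaches a limit; compound 2 gives > 25000000 nM. Among the measured compounds shown here, compound 3 `CC(C)c1ccc2c(c1)[n+]([O-])c(NCCN1CCCCC1)n[n+]2[O-]` is the only one with a number: compound 3 gives 18000000 nM. The change isopropyl in place of hydrogen on an aromatic carbon brings an at least 2.7-fold lower number from compound 1 to compound 3 (0.43 log units; beyond the scatter). The change dipropylamino in place of piperidin-1-yl on a saturated chain carbon, two bonds along the chain from a nitrogen on an aromatic ring brings a step that the two limits leave unreadable from compound 1 to compound 2, so its size is not known. Compound 4 `CCCN(CCC)CCNc1n[n+]([O-])c2ccc(C(C)C)cc2[n+]1[O-]` is not yet measured; it carries the same change from compound 3, (dipropylamino in place of piperidin-1-yl on a saturated chain carbon, two bonds along the chain from a nitrogen on an aromatic ring), and the two cores differ by isopropyl in place of hydrogen on an aromatic carbon. The step from compound 3 to compound 4 is expected to be a 1.1-fold higher number from compound 3 to compound 4 (0.05 log units; within the scatter), resting only on compound 3 at 18000000 nM with no readable guide from the earlier pair. Compound 4 is estimated at 20000000 nM, between 7000000 nM and 60000000 nM.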

Compound 4, solubility: 39000000 nM
Compound 4: the middle estimate sits 2.0-fold (0.29 log units) below what was measured; low and high end bracket the measured number.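

With isopropyl on the core, dipropylamino in place of piperidin-1-yl gives in this assay a 2.2-fold higher number from compound 3 to compound 4 (0.34 log units; beyond the scatter), so the number is seen to rise on this one core only. The same change on the core without isopropyl and the isopropyl step on the dipropylamino compounds cannot be read, which leaves open whether the change carries from one core to the other, and compound 1 gives only a limit: the limit of > 49000000 nM in this assay, at which 1 of the 4 values shown sits. Compound 2 also gives only a limit: the limit of > 25000000 nM in this assay, at which 1 of the 4 values shown sits.

Other amines on the chain, such as morpholin-4-yl or dimethylamino, remain open. So does a longer chain carrying the amine, or methoxy in place of isopropyl.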